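A few compounds are considered here, and "the series" means these few. Any claim that something is new, unique, unknown or untested is made for them only; others in the source may bear on it.

Of the compounds shown here, three built on one shared core have been tested in a functional assay on MGC-803 cells (Homo sapiens) for inhibition, read by MTT assay, with a stated time of 48 h; a lower number here means a stronger inhibitor, a higher number a weaker inhibitor. Compound 1 `COc1ccc(CN(c2cc(OC)c(OC)c(OC)c2)S(=O)(=O)c2ccc(C)cc2)cc1` carries a 4-methylphenyl on the sulfonyl sulfur, and in this assay compound 1 gives 4340 nM. Compound 2 `COc1ccc(CN(c2cc(OC)c(OC)c(OC)c2)S(=O)(=O)c2ccccc2)cc1` carries a plain phenyl there. For compound 2 the assay reports only a limit, > 50000 nM, which is the limit of > 50000 nM in this assay, at which 1 of the 3 values shown sits. Compound 3 `COc1ccc(CN(c2cc(OC)c(OC)c(OC)c2)S(=O)(=O)c2ccc(OC)c(OC)c2)cc1` carries a 3,4-dimethoxyphenyl on the sulfonyl sulfur, and compound 3 gives 8310 nM. Among the compounds with values here, of the two plain numbers, the one for compound 3 is the higher, but the gap stays inside the scatter: a 1.9-fold higher number from compound 1 to compound 3 (0.28 log units; within the scatter). The two steps that cross the scatter both involve the bare phenyl of compound 2: an at least 11-fold higher number from compound 1 to compound 2 (1.06 log units; beyond the scatter) and an at least 6.0-fold lower number from compound 2 to compound 3 (0.77 log units; beyond the scatter).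

Compound 4 `COc1ccc(CN(c2cc(OC)c(OC)c(OC)c2)S(=O)(=O)c2c(C)cc(C)cc2C)cc1` has not yet been measured. It differs from compound 3 in one place: 2,4,6-trimethylphenyl in place of 3,4-dimethoxyphenyl on a sulfonyl sulfur. All three measured steps bear on this change, since each alters what sits on the sulfonyl ring. A single methyl and a pair of methoxy groups gave numbers within the scatter of each other, while the bare ring sat at the limit. Three methyls are therefore expected to give a number near that of compound 1, so compound 4 is estimated at 4000 nM, in a range from 1000 nM to 20000 nM, meaning an expected 2.1-fold lower number from compound 3 to compound 4 (0.32 log units; beyond the scatter).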

Compound 4, half-maximal inhibitory concentration: 6440 nM
Compound 4: the middle estimate sits 1.6-fold (0.21 log units) below what was measured; the measured number falls inside the stated range.
By their numbers in this assay, from the lowest: compounds 1, 4 and 3 (each within the scatter of the next). At a limit, above all of these: compound 2.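

In this assay, the 2,4,6-trimethylphenyl on the sulfonyl sulfur of compound 4 stays level with both other substituted rings: a 1.3-fold lower number from compound 3 to compound 4 (0.11 log units; within the scatter), and a 1.5-fold higher number from compound 1 to compound 4 (0.17 log units; within the scatter). This adds something new, showing that a ring carrying only methyl groups, with no oxygen on it, does as well at this position as the 3,4-dimethoxyphenyl, while the separation from the bare phenyl holds, with an at least 7.7-fold lower number from compound 2 to compound 4 (0.89 log units; beyond the scatter). For compound 2 the assay gives no plain number, only a limit: the limit of > 50000 nM in this assay, at which 1 of the 4 values shown sits.

On these data alone, the substituents on this ring are so far only methyl and methoxy groups, so it remains open whether a chlorine, a nitro group, an amine or a carboxylic acid there would match these numbers, or move them well beyond the scatter in either direction. Since the three substituted rings cannot be told apart in this assay, the compounds shown also do not settle how many groups the ring needs, or whether changes elsewhere on the shared core would matter more than this one.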